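Working notes: replacing carbamoyl with difluoromethoxy on the core

The compounds below may be only part of what the source reports. "The series", "measured", "known", "first", "only" and "open" are said of these compounds alone.

Among the measured compounds shown here, compound 2 `NC(=O)c1ccccc1C1Cc2nccn2C1` stands at the higher end of the two numbers so far: in a functional assay on CHO cells for agonist activity at Alpha-1A adrenergic receptor (Homo sapiens), read by FLIPR and calcium flux (on this read-out lower numbers stand for an effect already at smaller amounts and higher numbers for an effect only at larger amounts of compound), compound 2 gives 371 nM, while compound 1 `COCc1ccccc1C1Cc2nccn2C1` gives 82 nM. For the measured compounds named here, the only measured step, a 4.5-fold higher number from compound 1 to compound 2 (0.66 log units; beyond the scatter), runs from the methoxymethyl of compound 1 to the carbamoyl of compound 2.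

Compound 3 `FC(F)Oc1ccccc1C1Cc2nccn2C1` is not yet measured. It differs from compound 2 in one place: difluoromethoxy in place of carbamoyl on an aromatic carbon. The step from compound 1 to compound 2 bears on this change, since it swapped methoxymethyl for the same carbamoyl at the same aromatic carbon and raised the number beyond the scatter. Removing the carbamoyl in favour of an ether-type group is expected to undo part of that rise, so a modest step downward, a 3.4-fold lower number from compound 2 to compound 3 (0.53 log units; beyond the scatter), is expected. Compound 3 is therefore estimated at 110 nM, with a range from 35 nM to 350 nM.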

Compound 3, half-maximal effective concentration in the Alpha-1A adrenergic receptor assay: 11 nM
Compound 3: middle estimate off by 10-fold (1.00 log units), on the high side; measured number outside the range, below it.
By their numbers in the Alpha-1A adrenergic receptor assay, from the lowest: compound 3; then compound 1; then compound 2.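

Among the compounds shown here, at this aromatic carbon the number in the Alpha-1A adrenergic receptor assay depends on the substituent far more than the single earlier step, a 4.5-fold higher number from compound 1 to compound 2 (0.66 log units; beyond the scatter), showed: compound 2 gives 371 nM and compound 3 gives 11 nM, so difluoromethoxy in place of carbamoyl brings a 34-fold lower number from compound 2 to compound 3 (1.53 log units; beyond the scatter), a large step. The change does more than reverse the earlier rise, since difluoromethoxy in place of methoxymethyl gives a 7.5-fold lower number from compound 1 to compound 3 (0.87 log units; beyond the scatter), which puts compound 3 lowest of the three and shows that these two oxygen-bearing groups are not interchangeable here. Nothing available accounts for these steps.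

Going by these compounds, whether the low number rests on the fluorine atoms or on the oxygen attached to the ring stays open, and methoxy or trifluoromethoxy at the same carbon would bear on that. In a physicochemical assay for lipophilicity, at pH 7.4 (on this read-out higher numbers stand for higher lipophilicity and lower numbers for lower lipophilicity), compound 3 gives 2.3, while compound 2 stands at "not determined" (no result reported), so no step on that read-out can be read from the compounds shown.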